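From benzyl to 3-methylphenyl at the stability limit

The source may hold more compounds than are shown below. What is called first, only, known or untested is meant among the compounds shown, and "the series" means these compounds.

In an ADME assay on microsomes from liver (Mus musculus) for metabolic stability, read by LC-MS, with NADPH named in the record, with a stated time of 60 min, tested at 1 uM, in the absence of a further agent (on this read-out lower numbers stand for a less stable compound and higher numbers for a more stable compound), compound 1 (`CCCCCC(=O)N[C@@H]1CCN(c2cc(C)nn3c(-c4ccc(OC)c(OC)c4)c(C)nc23)C1`) gives > 95% as a limit of the assay and not a number. Compound 2 (`COc1ccc(-c2c(C)nc3c(N4CC[C@@H](NC(=O)OCc5ccccc5)C4)cc(C)nn23)cc1OC`) gives > 95% as a limit too and has no exact position. The two measured compounds offer the limit of > 95% in this assay, at which 2 of the 2 values shown sit, and nothing finer. Going by the values given here, the only measured step is a step that the two limits leave unreadable from compound 1 to compound 2 for benzyloxy in place of pentyl on a carbonyl carbon, so no size can be carried over from it.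

Compound 3 (`COc1ccc(-c2c(C)nc3c(N4CC[C@@H](NC(=O)Oc5cccc(C)c5)C4)cc(C)nn23)cc1OC`) differs from compound 2 by 3-methylphenyl in place of benzyl on an oxygen next to a carbonyl group in one place, with 3-methylphenyl in place of benzyl on an oxygen next to a carbonyl group. Among the compounds with values here, no measured step covers this change. The reading for compound 2 sits at the top of the scale, so any readable movement in this assay can only be downward. The estimated change is a number at least 7 percentage points lower from compound 2 to compound 3 (that floor lies within the scatter) as a small fall, if it can be read at all. For compound 3 the expected value is 88% with an estimated range from 65% to 100% in this working estimate.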

Compound 3, percent of the compound remaining: > 95%
Compound 3: no number, only a limit; the forecaster's own chance of this, stated with the estimate: 45%; at least 7 percentage points between middle value and limit.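

In this assay compound 3 gives > 95%, a limit of the assay and not a number. No new step can be read between compound 3 and either compound 1 or compound 2, because all three compounds stand at the same limit: the limit of > 95% in this assay, at which 3 of the 3 values shown sit.

The compounds shown leave open whether pentyl, benzyloxy and 3-methylphenoxy differ at all in this assay.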